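The compounds below may be only part of what the source reports. "The series", "measured", "known", "first", "only" and "open" are said of these compounds alone.

Of the compounds shown here, two from the same series have been measured in an assay for inhibition of Amine oxidase [flavin-containing] A (Bos taurus), read by fluorescence, with a stated time of 30 min; a higher number here means a weaker inhibitor, a lower number a stronger inhibitor. Compound 1, `Cc1c(C)c2ccc(OCC(=O)NN)cc2oc1=O`, carries two methyl groups on its core and a hydrazide side chain; in this assay compound 1 gives 0.00501 nM. Compound 2, `Cc1cc(=O)oc2cc(OCc3nnc(S)s3)ccc12`, carries one methyl group and a thiadiazole thiol side chain; in this assay compound 2 gives 0.011 nM. Compound 2 therefore stands at the higher of the two numbers, and the gap between compound 1 and compound 2 is beyond the usual scatter of repeated measurements.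

Compound 3, `Cc1c(C)c2ccc(OCc3nnc(S)s3)cc2oc1=O`, keeps the side chain of compound 2 and differs from it in one place: methyl in place of hydrogen on an aromatic carbon. Within the data shown here, with that change compound 3 matches the two-methyl pattern of compound 1 while retaining the side chain of compound 2, so no measured pair shows this exact step on its own. The expectation is a small step, a 1.4-fold lower number from compound 2 to compound 3 (0.14 log units; within the scatter), toward a lower number, not clearly beyond the scatter. For compound 3 the estimated inhibition constant in this assay is 0.008 nM, within a range from 0.003 nM to 0.025 nM.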

Compound 3, inhibition constant: 0.00637 nM
For compound 3 the middle estimate is 1.3-fold (0.10 log units) above the measured one; measured number inside the range.
By their numbers in this assay, from the lowest: compounds 1, 3 and 2 (each within the scatter of the next, the first and the last beyond it).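

In this assay, methyl in place of hydrogen on this aromatic carbon of the six-membered aromatic ring with 1 oxygen gives a 1.7-fold lower number from compound 2 to compound 3 (0.24 log units; within the scatter) and so, with the 5-sulfanyl-1,3,4-thiadiazol-2-yl side chain in place, this change cannot be told apart from the variation between repeated measurements. Among these compounds, compound 3 also allows the two side chains to be compared directly on one core for the first time: 5-sulfanyl-1,3,4-thiadiazol-2-yl in place of aminocarbamoyl gives a 1.3-fold higher number from compound 1 to compound 3 (0.10 log units; within the scatter) and thus this much larger change in structure also leaves no difference that can be separated from that variation. The compounds shown offer no independent measurement that could explain either result.

On these data alone, it remains open whether an ethyl group, a chlorine atom or an amine on the same aromatic carbon would give a step beyond the scatter, and whether methyl there would give a similar step with the aminocarbamoyl side chain. As far as these compounds go, it is also open how a carboxylic acid or a longer chain in place of either side-chain end would behave in this assay on this core.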